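Formamide series: ring-size change on the amide nitrogen

The source may report more compounds than this note shows. Statements on the series, on what has been measured and on what is new or still open speak of the compounds shown alone.

Measured so far:
compound 1 `O=CN(C1CCCC1)C1CC1` — 4600000 nM
compound 2 `CC(C)CNC=O` — 26000 nM

Two compounds have numbers in an assay on isolated protein for inhibition of all-trans-retinol dehydrogenase [NAD(+)] ADH1B (Homo sapiens); on this read-out lower numbers stand for stronger inhibition and higher numbers for weaker inhibition. Compound 1 `O=CN(C1CCCC1)C1CC1` gives 4600000 nM and stands as the higher of the two numbers. Compound 2 `CC(C)CNC=O` gives 26000 nM, a considerably lower number; the two compounds differ in more than one place, so the gap between them is recorded only as what the two values show and is not a single step.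

Compound 3 `O=CN(C1CCCC1)C1CCC1` has not been measured. It is derived from compound 1 by a single change: cyclobutyl in place of cyclopropyl on an amide-type nitrogen, in words cyclobutyl in place of cyclopropyl on an amide-type nitrogen. Going by the values given here, no comparable step between measured compounds exists in this set, so there is no precedent to lean on. The expected step in this assay from compound 1 to compound 3 is a 1.5-fold lower number from compound 1 to compound 3 (0.19 log units; within the scatter), a change that may well fall inside the usual scatter. Compound 3 is therefore estimated at 3000000 nM, with a range from 900000 nM to 10000000 nM.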

Compound 3, inhibition constant: 10000000 nM
For compound 3 the middle estimate is 3.3-fold (0.52 log units) below the measured one, within the range that was stated.
By their numbers in this assay, from the lowest: compound 2; then compound 1; then compound 3.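

In this assay, this position has its first single-place comparison: cyclobutyl in place of cyclopropyl on the amide-type nitrogen gives a 2.2-fold higher number from compound 1 to compound 3 (0.34 log units; beyond the scatter), a modest step but one that lies beyond the usual scatter. The position is therefore not indifferent to this change, and of these two rings the cyclobutyl, with 4 heavy atoms against 3, goes with the weaker inhibition, as compound 3 gives 10000000 nM; this is a single pair and sets no trend across ring sizes. No available measurement bears on what lies behind this step.

Going by these compounds alone, whether the direction holds for a cyclohexyl ring or for an open chain such as isopropyl at the same place on the nitrogen remains open, as only two groups can be compared there so far. Compound 2 at 26000 nM differs from compound 1 in more than one place, so a formamide carrying cyclopentyl alone on the nitrogen, with the amide hydrogen kept, would be the kind of compound needed to connect the two.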